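Trading the Benzyl Substituent for a Methoxy Group

The source may report more compounds than this note shows. Statements on the series, on what has been measured and on what is new or still open speak of the compounds shown alone.

The measured compounds in a functional assay on HPAC cells (Homo sapiens) for inhibition, read by MTT assay, with a stated time of 72 h; a lower number here means a stronger inhibitor of growth, a higher number a weaker inhibitor of growth:
compound 1, `CC(C)(C)c1ccc(CNCCCNS(=O)(=O)c2cc(C(F)(F)F)cc(C(F)(F)F)c2)cc1`, 2300 nM
compound 2, `O=S(=O)(NCCCNCc1ccc(Br)cc1)c1cc(C(F)(F)F)cc(C(F)(F)F)c1`, 2900 nM
compound 3, `O=S(=O)(NCCCNCc1ccc(Cl)cc1)c1cc(C(F)(F)F)cc(C(F)(F)F)c1`, 2800 nM

Compound 1 gives the lowest of the three numbers, yet both other compounds lie within the scatter of it: a 1.3-fold higher number from compound 1 to compound 2 (0.10 log units; within the scatter) and a 1.2-fold higher number from compound 1 to compound 3 (0.09 log units; within the scatter), and between them a 1.0-fold lower number from compound 2 to compound 3 (0.02 log units; within the scatter). Three different groups on the benzyl ring have thus left this assay essentially unmoved.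

The unmeasured compound 4, `COc1ccccc1CNCCCNS(=O)(=O)c1cc(C(F)(F)F)cc(C(F)(F)F)c1`, differs from compound 1 by 2-methoxyphenyl in place of 4-(tert-butyl)phenyl on a saturated chain carbon bound to an amine nitrogen. Among the measured compounds shown here, no measured pair shows this exact change, but the two steps that bear on it, from compound 1 to compound 2 and from compound 1 to compound 3, both replace the tert-butyl on the same ring and both stay within the scatter. The expectation for compound 4 in this assay is therefore a step of no more than the scatter, possibly toward a slightly higher number, as a 1.3-fold higher number from compound 1 to compound 4 (0.12 log units; within the scatter). Compound 4 is estimated at 3000 nM, within a range from 1400 nM to 6500 nM.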

Compound 4, concentration for 50% growth inhibition: 2400 nM
Compound 4: middle estimate off by 1.3-fold (0.10 log units), on the high side; the range from low to high includes it.
By their numbers in this assay, from the lowest: compounds 1, 4, 3 and 2 (each within the scatter of the next).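

Replacing 4-(tert-butyl)benzyl with 2-methoxybenzyl alters more than the group on the ring: the substituent now stands in a different ring position, is smaller in heavy atoms and brings a hydrogen-bond acceptor, yet this assay records a 1.0-fold higher number from compound 1 to compound 4 (0.02 log units; within the scatter). The halogen compounds give the same picture, with a 1.2-fold lower number from compound 3 to compound 4 (0.07 log units; within the scatter) and a 1.2-fold lower number from compound 2 to compound 4 (0.08 log units; within the scatter), so the assay does not separate these four benzyl groups, and this place tolerates a change of group and ring position alike. Nothing measured here accounts for this flat reading.

Still open, as far as these compounds go, is whether any group at this place would step beyond the scatter, such as 4-methoxyphenyl, a pyridine ring or a ring bearing a carboxylic acid. A longer chain linking the amine and the sulfonamide also remains untested in the compounds shown.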